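Piperidinyl sulfonamide catechol amides: furanylmethyl for fluorobenzyl

The compounds below may be only part of what the source reports. "The series", "measured", "known", "first", "only" and "open" are said of these compounds alone.

Compound 1 `O=C(NCc1ccc(F)cc1)c1cc(S(=O)(=O)N2CCCCC2)cc(O)c1O`: 13000 nM in an ADME assay on NCI-H630 cells (Homo sapiens) for cytotoxicity, read by MTT assay, with a stated time of 72 h; a lower number here means that less compound is tolerated, a higher number that more compound is tolerated
Compound 2 `CNS(=O)(=O)c1cc(O)c(O)c(C(=O)NCc2ccc(F)cc2)c1`: > 40000 nM, a limit of the assay
Compound 3 `CC(C)(C)NS(=O)(=O)c1cc(O)c(O)c(C(=O)NCc2ccc(F)cc2)c1`: > 10000 nM, a limit of the assay

Within the data shown here, compound 1 holds the only number in this assay; the other two values are limits. Varying the sulfonamide end gives an at least 3.0-fold higher number from compound 1 to compound 2 (0.48 log units; beyond the scatter). The steps a step that the limit leaves unreadable from compound 1 to compound 3 and a step that the two limits leave unreadable from compound 2 to compound 3 cannot be read, as the values sit at the limit of > 10000 nM in this assay, at which 1 of the 3 values shown sits, and (the limit of > 40000 nM in this assay, at which 1 of the 3 values shown sits). Compound 4 `O=C(NCc1ccco1)c1cc(S(=O)(=O)N2CCCCC2)cc(O)c1O` differs from compound 1 at the amide end instead: furan-2-yl in place of 4-fluorophenyl on a saturated chain carbon bound to an amide-type nitrogen. Among the measured compounds shown here, no measured step touches this side of the shared core, and the sulfonamide piperidin-1-yl of compound 1 is kept. The expectation for this assay is therefore a step within the scatter, no change at the digits printed from compound 1 to compound 4 (within the scatter). Compound 4 is estimated at 13000 nM, in the range 5000 nM to 35000 nM.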

Compound 4, half-maximal cytotoxic concentration: 33000 nM
Compound 4: the middle estimate sits 2.5-fold (0.40 log units) below what was measured, within the range that was stated.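

In this assay, the amide end now has a readable step: furan-2-yl in place of 4-fluorophenyl gives a 2.5-fold higher number from compound 1 to compound 4 (0.40 log units; beyond the scatter). The earlier compounds shown here varied only the sulfonamide end, so this shows that the number also responds to a change at the amide end with the piperidin-1-yl kept. Nothing measured here accounts for this step.

From the compounds shown here alone, whether the step comes from the furan-2-yl ring or from the absence of fluorine stays open; an unsubstituted phenyl at this place would separate the two. Also open, going by these compounds, is whether the change carries over to the methylamino and (tert-butyl)amino sulfonamides.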